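The compounds below may be only part of what the source reports. "The series", "measured", "known", "first", "only" and "open" are said of these compounds alone.

In a functional assay on the whole organism with Mus musculus as the target (on this read-out higher numbers stand for an effect only at larger amounts of compound and lower numbers for an effect already at smaller amounts), compound 1 `CN1C(=O)CCC(Cc2ccc(Br)cc2)C1=O` gives 143 mg/kg, compound 2 `O=C1CCC(Cc2ccc(I)cc2)C(=O)N1` gives 87.2 mg/kg and compound 3 `O=C1CCC(Cc2ccc(Br)cc2)C(=O)N1` gives 56.3 mg/kg. Compound 1 lies within the scatter of compound 2 and beyond the scatter of compound 3 on the same read-out. Compound 4 `CN1C(=O)CCC(Cc2ccc(Cl)cc2)C1=O` keeps the methyl of compound 1 and changes only the halogen (chloro in place of bromo on an aromatic carbon): chloro in place of bromo on an aromatic carbon, para to a large group. Among the measured compounds shown here, the only measured halogen step is bromo in place of iodo (a 1.5-fold lower number from compound 2 to compound 3 (0.19 log units; within the scatter)), which lies within the scatter and sits on the core without the methyl. The step of hydrogen in place of methyl (a 2.5-fold lower number from compound 1 to compound 3 (0.40 log units; beyond the scatter)) is modest, lies beyond the scatter and leaves the halogen untouched. For the measured compounds named here, no chloro compound has been measured on either core, so the direction stays open. No step beyond the scatter is expected in this assay for this change, and the estimated step is small (a 1.1-fold lower number from compound 1 to compound 4 (0.04 log units; within the scatter)). Compound 4 is expected at 130 mg/kg (estimated range from 70 mg/kg to 240 mg/kg).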

Compound 4, dose for half-maximal effect: 124 mg/kg
Estimate against measurement, compound 4: 1.0-fold (0.02 log units) above; measured number inside the range.
By their numbers in this assay, from the lowest: compounds 3, 2, 4 and 1 (each within the scatter of the next, the first and the last beyond it).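

Swapping bromo for chloro on an aromatic carbon, para to a large group, on the methylated core gives a 1.2-fold lower number from compound 1 to compound 4 (0.06 log units; within the scatter) in this assay, the first halogen step on this core. With a 1.5-fold lower number from compound 2 to compound 3 (0.19 log units; within the scatter) on the core without the methyl, both halogen steps shown at this position lie within the scatter, so no halogen order can be read from the compounds shown, and the step beyond the scatter remains the one at the ring nitrogen. No supporting data bear on this result.

Still open, as far as these compounds go, is whether hydrogen in place of methyl on the ring nitrogen gives a similar step with chloro on the ring. Also open, from the compounds shown here alone, is how a group other than a halogen, such as an amine, a carboxylic acid or a longer chain, would read at this position in this assay.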